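The source may hold more compounds than are shown below. What is called first, only, known or untested is meant among the compounds shown, and "the series" means these compounds.

Measured compounds:
compound 1, `COc1ccc(C2SCC(=O)N2c2ccc3c(C)cc(=O)[nH]c3c2)cc1` — 21.4%
compound 2, `COc1cc(C2SCC(=O)N2c2ccc3c(C)cc(=O)[nH]c3c2)ccc1O` — 12.4%

In a functional assay on the whole organism (strain albino) for inhibition, with Rattus norvegicus as the target, read by paw edema, with stated times of 1 h and 3 h, at a dose of 100 mg/kg by the oral route (on this read-out lower numbers stand for less inhibition and higher numbers for more inhibition at the one dose given (going by the name of the read-out)), compound 2 gives 12.4%. Among the compounds with values here, the only other number on the shared core comes from compound 1, which in this assay gives 21.4%; the one step that connects the two, a number 9 percentage points lower from compound 1 to compound 2 (within the scatter), stays within the scatter, so the two compounds cannot be told apart on this read-out.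

Compound 3, `COc1ccc(C2SCC(=O)N2c2ccc3c(C)cc(=O)[nH]c3c2)cc1OC`, has not yet been measured. The change from compound 2 to compound 3 is methyl in place of hydrogen on an oxygen on an aromatic ring. Within the data shown here, no measured step touches an oxygen on the aromatic ring in this way; the step of a number 9 percentage points lower from compound 1 to compound 2 (within the scatter) alters the same aryl group, but in a different way and with a different result, and it did not move the read-out beyond the scatter. Among the measured compounds shown here, with only that step to lean on, the expectation is that compound 3 will also lie within the scatter of compound 2 in this assay, with no direction favoured.

Compound 3 is therefore estimated at 17%, between 5% and 30%. The step this estimate implies, a number 4.6 percentage points higher from compound 2 to compound 3 (within the scatter), is expected to be small.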

Compound 3, a percentage reported as inhibition, in the whole organism at one dose (the size of the read-out at that dose, not a potency): 20.6%
Compound 3: the middle estimate sits 3.6 percentage points below what was measured; the measured number falls inside the stated range.
By their numbers in this assay, from the lowest: compounds 2, 3 and 1 (each within the scatter of the next).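

In this assay, within the data shown here, the first step at this oxygen on the aromatic ring, hydroxy to methoxy, reads as a number 8.2 percentage points higher from compound 2 to compound 3 (within the scatter), so on this read-out a free hydroxy and a methoxy at this place cannot be told apart. The step that sets a methoxy in place of hydrogen on an aromatic carbon of the same aryl group reads as a number 0.8 percentage points lower from compound 1 to compound 3 (within the scatter), which shows that hydrogen and methoxy at that carbon cannot be told apart here either, and the three compounds together show no pattern across these aryl groups. The data shown offer no measurement that would account for these readings.

The compounds shown leave open whether any replacement on this aryl group can move the read-out beyond the scatter, for instance an amine or a carboxylic acid on the aromatic ring, or a longer chain such as ethoxy on the oxygen. They also leave open how these compounds would compare at any other dose, as each number here comes from a single oral dose.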